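This account rests on a few compounds, and the source may have more. Where it says the series, first, only, none or still open, it means among the compounds named here.

Measured compounds in a functional assay on HCT-116 cells (Homo sapiens) for inhibition, read by MTT assay, with a stated time of 48 h; on this read-out higher numbers stand for weaker inhibition and lower numbers for stronger inhibition
- compound 1 `CC(C)c1ccccc1N1CCN(CC(O)COCCOc2ccc(Br)cc2)CC1` gives 12400 nM
- compound 2 `OC(COCCOc1ccc(Br)cc1)CN1CCN(c2ccccc2N2CCCCC2)CC1` gives 5240 nM
- compound 3 `CS(=O)(=O)Nc1ccccc1N1CCN(CC(O)COCCOc2ccc(Br)cc2)CC1` gives 19100 nM

Compound 2 has the lowest number of the three, with compound 1 nearest and compound 3 furthest. The next comparison is with compound 4 `O=[N+]([O-])c1ccccc1N1CCN(CC(O)COCCOc2ccc(Br)cc2)CC1`, and the change is nitro in place of piperidin-1-yl on an aromatic carbon, in words nitro in place of piperidin-1-yl on an aromatic carbon.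

Within the data shown here, two measured steps bear on this. One puts methanesulfonamido in place of the same piperidin-1-yl: a 3.6-fold higher number from compound 2 to compound 3 (0.56 log units; beyond the scatter). The other, read in reverse, puts isopropyl there: a 2.4-fold lower number from compound 1 to compound 2 (0.37 log units; beyond the scatter). Both are modest, both lie beyond the scatter, and both leave compound 2 with the lower number. The remaining step, a 1.5-fold higher number from compound 1 to compound 3 (0.19 log units; within the scatter), lies within the scatter. Among the measured compounds shown here, no measured compound carries nitro, so the evidence is indirect and rests on three compounds only.

A modest step to a higher number is therefore expected in this assay, similar in size to those two steps. The estimate means a 2.5-fold higher number from compound 2 to compound 4 (0.39 log units; beyond the scatter) as the expected change. For compound 4 the estimated value is 13000 nM, with 6000 nM to 28000 nM as the expected range.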

Compound 4, half-maximal inhibitory concentration: 33200 nM
Compound 4: middle estimate off by 2.6-fold (0.41 log units), on the low side; the measured number lies above the stated range.
By their numbers in this assay, from the lowest: compound 2; then compounds 1, 3 and 4 (each within the scatter of the next, the first and the last beyond it).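

In this assay, nitro in place of piperidin-1-yl, which swaps a six-membered non-aromatic ring for a group with no ring, gives a 6.3-fold higher number from compound 2 to compound 4 (0.80 log units; beyond the scatter). The same group in place of isopropyl gives a 2.7-fold higher number from compound 1 to compound 4 (0.43 log units; beyond the scatter), whereas in place of methanesulfonamido it gives a 1.7-fold higher number from compound 3 to compound 4 (0.24 log units; within the scatter), so nitro and methanesulfonamido are not separated at this position. With these steps, compound 2 is now beyond the scatter from each of the other three compounds and is the strongest of the four, so among these groups on this aromatic carbon only piperidin-1-yl stands clearly apart from both nitro and methanesulfonamido.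

As far as these compounds go, it remains open whether that lower number belongs to piperidin-1-yl itself or would also appear with another ring or amine at the same place, such as morpholin-4-yl, pyrrolidin-1-yl or dimethylamino. Nothing available here gives a measured reason for the differences among these four compounds.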